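Shortening the Linker of an Iodoacetamide-Bearing Nucleotide

The source may report more compounds than this note shows. Statements on the series, on what has been measured and on what is new or still open speak of the compounds shown alone.

Compound 1, `Nc1ncnc2c1nc(NCCCCCCCCNC(=O)CI)n2[C@@H]1O[C@H](COP(=O)(O)OP(=O)(O)OP(=O)(O)O)[C@@H](O)[C@H]1O`, was tested in an assay on isolated protein for inhibition of hexokinase-3 (Rattus norvegicus), with a stated time of 6 h, tested at 10 mM; on this read-out lower numbers stand for less inhibition and higher numbers for more inhibition at the one concentration tested (going by the name of the read-out). In this assay compound 1 gives 0%. Compound 2, `O=C(CI)NCCCCC(=O)NCCCCCCNc1ncnc2c1ncn2[C@@H]1O[C@H](COP(=O)(O)OP(=O)(O)OP(=O)(O)O)[C@@H](O)[C@H]1O`, carries a longer chain between the core and the iodoacetamide end; in this assay compound 2 gives 0%. Compound 2 thus stands level with compound 1 at the digits reported, and the two values lie within the scatter of each other.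

Compound 3, `O=C(CI)NCCC(=O)NCCCCCCNc1ncnc2c1ncn2[C@@H]1O[C@H](COP(=O)(O)OP(=O)(O)OP(=O)(O)O)[C@@H](O)[C@H]1O`, has not been measured. It differs from compound 2 by ((iodomethyl)carbonyl)amino in place of 2-(((iodomethyl)carbonyl)amino)ethyl on a saturated chain carbon, two bonds along the chain from a carbonyl carbon. Among the compounds with values here, no measured pair shows what such a shortening does here. Because compound 2 gives 0% and compound 1 gives 0% with a different chain, the step from compound 2 to compound 3 is expected to be no change at the digits printed from compound 2 to compound 3 (within the scatter), which is none beyond the scatter. For compound 3 the expected value in this assay is 0%, with a range from 0% to 10%.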

Compound 3, a percentage reported as inhibition, at one concentration (the size of the read-out at that concentration, not a potency): 0%
The estimate for compound 3 equals the measured number at the digits printed; low and high end bracket the measured number.
By their numbers in this assay, from the lowest: compounds 1, 2 and 3 (each within the scatter of the next).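

In this assay, putting ((iodomethyl)carbonyl)amino in place of 2-(((iodomethyl)carbonyl)amino)ethyl, on a saturated chain carbon, two bonds along the chain from a carbonyl carbon, gives no change at the digits printed from compound 2 to compound 3 (within the scatter). Within the data shown here, this is the only measured step at this position, and it shows that this shortening of the chain, with the iodoacetamide end kept, does not move the read-out beyond the scatter. Nothing measured alongside these values bears on why the read-out stays as it does.

Open, as far as these compounds go, is whether a different group at this place, such as an amine, a carboxylic acid or a longer chain, would give a value beyond the scatter. Also open, from the compounds shown here alone, is whether the same shortening would matter on a compound that shows measurable inhibition.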